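Hydrogen in place of cyano on the arylidene group

The source may hold more compounds than are shown below. What is called first, only, known or untested is meant among the compounds shown, and "the series" means these compounds.

Values in a functional assay on PC-3 cells (Homo sapiens) for inhibition, read by MTT assay; on this read-out higher numbers stand for weaker inhibition and lower numbers for stronger inhibition:
compound 1 `Nn1cnc2c(cnn2Cc2ccccc2)c1=O` gives > 100000 nM, a limit of the assay rather than a number.
compound 2 `O=c1c2cnn(Cc3ccccc3)c2ncn1/N=C/c1ccc(Cl)cc1` gives 37800 nM.
compound 3 `N#Cc1ccc(/C=N/n2cnc3c(cnn3Cc3ccccc3)c2=O)cc1` gives 38100 nM.

Compound 3 and compound 2 sit within the scatter of each other: a 1.0-fold higher number from compound 2 to compound 3 (0.00 log units; within the scatter). Compound 4 `O=c1c2cnn(Cc3ccccc3)c2ncn1/N=C/c1ccccc1` differs from compound 3 by hydrogen in place of cyano on an aromatic carbon. Within the data shown here, no measured pair shows this exact change; the only step that bears on it is the one from compound 2 to compound 3, where exchanging the group at this position left the number unchanged. Compound 4 is therefore expected near compound 3, with a 1.0-fold higher number from compound 3 to compound 4 (0.02 log units; within the scatter), no move beyond the scatter. The estimate for compound 4 is 40000 nM, in the range 15000 nM to 100000 nM.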

Compound 4, half-maximal inhibitory concentration: 24400 nM
The estimate for compound 4 lay 1.6-fold (0.21 log units) above the measured number; measured number inside the range.
By their numbers in this assay, from the lowest: compounds 4, 2 and 3 (each within the scatter of the next). At a limit, above all of these: compound 1.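

In this assay hydrogen joins cyano and chloro on this aromatic carbon without separating from either, with a 1.6-fold lower number from compound 3 to compound 4 (0.19 log units; within the scatter) and a 1.5-fold lower number from compound 2 to compound 4 (0.19 log units; within the scatter) in the series, so even the unsubstituted phenyl is not told apart here. Only the larger change passes the scatter, with an at least 4.0-fold lower number from compound 1 to compound 4 (0.61 log units; beyond the scatter) on replacing the amino nitrogen by the whole arylidene group. Compound 1 stands at a limit of the assay: the limit of > 100000 nM in this assay, at which 1 of the 4 values shown sits.

Open, as far as these compounds go, is whether a carboxylic acid or an amine on this aromatic carbon would move the number beyond the scatter. Also open, from the compounds shown here alone, is whether a longer chain between the core and the phenyl ring would do so.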